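Chain lengthening on both sides of the shared core

The source may hold more compounds than are shown below. What is called first, only, known or untested is meant among the compounds shown, and "the series" means these compounds.

Three measured compounds carry the same two end groups on a shared core and differ only in the lengths of their saturated chains. In an assay on SW1353 cells (Homo sapiens) for inhibition, read by a luciferase reporter, with stated times of 30 min and 8 h (a higher number here means a weaker inhibitor, a lower number a stronger inhibitor), compound 1 `O=c1oc2ccccc2n1CCCCCN1CCN(CCn2c(=O)oc3ccccc32)CC1` gives 4780 nM. In this assay compound 2 `O=c1oc2ccccc2n1CCCCCCN1CCN(CCn2c(=O)oc3ccccc32)CC1` gives 3070 nM; the change is a group of 11 heavy atoms (8 carbon, 1 nitrogen, 2 oxygen; one five-membered aromatic ring with 2 hetero atoms, one six-membered aromatic ring of carbon only) in place of a group of 10 heavy atoms (7 carbon, 1 nitrogen, 2 oxygen; one five-membered aromatic ring with 2 hetero atoms, one six-membered aromatic ring of carbon only), on a saturated chain carbon, five bonds along the chain from an amine nitrogen in a ring, and the step is a 1.6-fold lower number from compound 1 to compound 2 (0.19 log units; within the scatter). In this assay compound 3 `O=c1oc2ccccc2n1CCCCCCN1CCN(CCCCn2c(=O)oc3ccccc32)CC1` gives 1240 nM, the step being a 2.5-fold lower number from compound 2 to compound 3 (0.39 log units; beyond the scatter). Compound 3 and compound 1 differ in more than one place, and the difference between the two cores is not broken down here.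

Compound 4 `O=c1oc2ccccc2n1CCCCCCN1CCN(CCCCCn2c(=O)oc3ccccc32)CC1` has not yet been measured in this assay. Its change from compound 3 is a group of 11 heavy atoms (8 carbon, 1 nitrogen, 2 oxygen; one five-membered aromatic ring with 2 hetero atoms, one six-membered aromatic ring of carbon only) in place of a group of 10 heavy atoms (7 carbon, 1 nitrogen, 2 oxygen; one five-membered aromatic ring with 2 hetero atoms, one six-membered aromatic ring of carbon only), on a saturated chain carbon, four bonds along the chain from an amine nitrogen in a ring. This is the same kind of change as that made from compound 1 to compound 2, but not the same: there the place was five bonds along the chain from an amine nitrogen in a ring, here it is four bonds. The expected step is a 1.6-fold lower number from compound 3 to compound 4 (0.19 log units; within the scatter), which rests on compound 2 and its step of a 1.6-fold lower number from compound 1 to compound 2 (0.19 log units; within the scatter). The estimate for compound 4 in this assay is 800 nM, expected to fall between 400 nM and 1800 nM.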

Compound 4, half-maximal inhibitory concentration: 1400 nM
Estimate against measurement, compound 4: 1.8-fold (0.24 log units) below; the range from low to high includes it.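

In this assay the new step is a 1.1-fold higher number from compound 3 to compound 4 (0.05 log units; within the scatter), so lengthening the chain at this place, on a saturated chain carbon, four bonds along the chain from an amine nitrogen in a ring, gives no readable difference. Set beside the earlier step, the change behaves alike on the two cores as far as this assay can tell: the same change on two cores in this assay, a 1.6-fold lower number (0.19 log units; within the scatter) from compound 1 to compound 2 and a 1.1-fold higher number (0.05 log units; within the scatter) from compound 3 to compound 4, 1.8-fold (0.24 log units) apart, within the scatter of two such steps This shows only that the two steps cannot be told apart; both are small enough to lie within the scatter, their places are not the same, and they show neither a real effect of the change on either core nor how it would behave on any further core.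

The compounds shown leave open whether a longer chain on either side of the shared core would also give a step within the scatter, or one more like a 2.5-fold lower number from compound 2 to compound 3 (0.39 log units; beyond the scatter). They also leave open how an ether oxygen in the chain, or an amine or a carboxylic acid at its end, would read in this series.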